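Acetamido in Place of Dimethylamino on the Outer Ring

This account rests on a few compounds, and the source may have more. Where it says the series, first, only, none or still open, it means among the compounds named here.

Compound 1 `O=S(=O)(Nc1cccc(CO)c1)c1ccc(-c2ccccc2)cc1` gives 2200 nM in a functional assay on J774 cells (Mus musculus) for cytotoxicity, read by resazurin assay, with a stated time of 72 h; on this read-out lower numbers stand for stronger inhibition and higher numbers for weaker inhibition. Compound 2 `O=S(=O)(Nc1cccc(CO)c1)c1ccc(-c2ccc(Br)cc2)cc1` gives 2500 nM in this assay, and the step of a 1.1-fold higher number from compound 1 to compound 2 (0.06 log units; within the scatter) lies within the scatter. Compound 3 `CN(C)c1ccc(-c2ccc(S(=O)(=O)Nc3cccc(CO)c3)cc2)cc1` returns only > 5000 nM, which is a limit of this assay and not a number, namely (the limit of > 5000 nM in this assay, at which 1 of the 3 values shown sits). The two steps toward it, an at least 2.2-fold higher number from compound 1 to compound 3 (0.35 log units; beyond the scatter) and an at least 2.0-fold higher number from compound 2 to compound 3 (0.30 log units; that floor lies within the scatter), both run toward weaker inhibition. Compound 4 `CC(=O)Nc1ccc(-c2ccc(S(=O)(=O)Nc3cccc(CO)c3)cc2)cc1` differs from compound 3 by acetamido in place of dimethylamino on an aromatic carbon. For the measured compounds named here, no measured step carries acetamido; the steps that bear on this place show only that its substitution produced the one limit value. On this basis a step that the limit leaves unreadable from compound 3 to compound 4 is expected, with no change beyond the scatter. Compound 4 is estimated at 5500 nM, with a range from 2000 nM to 15000 nM, and may well again come back only as a limit.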

Compound 4, half-maximal inhibitory concentration: > 5000 nM
Compound 4: only a limit was reported; the forecaster's own chance of this, stated with the estimate: 55%; the middle value lies beyond the limit too.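

Compound 4, like compound 3, comes back in this assay only as a limit: the limit of > 5000 nM in this assay, at which 2 of the 4 values shown sit. This gives a second group on this aromatic carbon with a step from hydrogen of an at least 2.2-fold higher number from compound 1 to compound 4 (0.35 log units; beyond the scatter), while the step from bromo is an at least 2.0-fold higher number from compound 2 to compound 4 (0.30 log units; that floor lies within the scatter). The step between the two limits cannot be read, so acetamido and dimethylamino cannot be ordered here.

On these data alone, how far either group lies past the limit stays open. So does whether a methoxy group or a carboxylic acid at this place would also reach it.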